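This account rests on a few compounds, and the source may have more. Where it says the series, first, only, none or still open, it means among the compounds named here.

Of the compounds shown here, two measured so far share one core and differ only in the group on the urea nitrogen. Compound 1 `O=C(NC[C@@H](O)C(=O)O)c1ccc(CN(C(=O)Nc2cccc(Br)c2)c2ccc(C3CCCCC3)cc2)cc1` carries a 3-bromophenyl there, and in an in vitro assay on BHK cells for binding affinity to gastric inhibitory polypeptide receptor (Homo sapiens) (a lower number here means a stronger inhibitor, a higher number a weaker inhibitor), compound 1 gives 216 nM. Compound 2 `CC(C)(C)c1cccc(NC(=O)N(Cc2ccc(C(=O)NC[C@@H](O)C(=O)O)cc2)c2ccc(C3CCCCC3)cc2)c1` carries a 3-(tert-butyl)phenyl instead, and in this assay compound 2 gives 74 nM. Within the data shown here, that single exchange is the one step measured so far: a 2.9-fold lower number from compound 1 to compound 2 (0.47 log units; beyond the scatter). Among the measured compounds shown here, on these two numbers compound 2 stands as the stronger of the pair, with compound 1 as its only neighbour.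

Compound 3 `O=C(NC[C@@H](O)C(=O)O)c1ccc(CN(C(=O)Nc2cc(Cl)cc(Cl)c2)c2ccc(C3CCCCC3)cc2)cc1` has not been measured. The change is 3,5-dichlorophenyl in place of 3-(tert-butyl)phenyl on an amide-type nitrogen whose other neighbour is a carbonyl carbon. The step from compound 1 to compound 2 bears on it, since it shows that moving from a halogen on that ring to a tert-butyl gave a modest gain. Compound 3 moves back to halogens, now two chlorines, and nothing measured tells what a second chlorine adds. Compound 3 is therefore expected to sit somewhat weaker than compound 2, a step of roughly a 2.0-fold higher number from compound 2 to compound 3 (0.31 log units; beyond the scatter), so the estimate for compound 3 in this assay is 150 nM, with a range from 60 nM to 400 nM.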

Compound 3, half-maximal inhibitory concentration: 93 nM
Estimate against measurement, compound 3: 1.6-fold (0.21 log units) above; the measured number falls inside the stated range.
By their numbers in this assay, from the lowest: compounds 2 and 3 (each within the scatter of the next); then compound 1.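

Putting 3,5-dichlorophenyl in place of 3-(tert-butyl)phenyl on the amide-type nitrogen gives a 1.3-fold higher number from compound 2 to compound 3 (0.10 log units; within the scatter) in this assay so these two groups cannot be told apart here, and a tert-butyl group on this ring is not required for the level of binding seen with compound 2. Putting 3,5-dichlorophenyl in place of 3-bromophenyl gives a 2.3-fold lower number from compound 1 to compound 3 (0.37 log units; beyond the scatter) so halogen on this ring does not by itself go with the weaker number. Compound 1 is the weakest of the three. Nothing can yet be named that sets it apart beyond its different group. No outside measurement explains why the three groups rank in this way.

Still open, as far as these compounds go, is what a plain phenyl, a 3-chlorophenyl or a ring bearing an amine or a carboxylic acid would give at this nitrogen, which would show how much the ring's substituents matter and what kinds of group this position accepts. The three compounds also say nothing about how far these results would carry over if the rest of the shared core were changed.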